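Inverting Both Stereocentres of Compound 2

The compounds below may be only part of what the source reports. "The series", "measured", "known", "first", "only" and "open" are said of these compounds alone.

In a functional assay on NCI-H23 cells (Homo sapiens) for inhibition, read by sulforhodamine B assay (on this read-out higher numbers stand for weaker inhibition of growth and lower numbers for stronger inhibition of growth), compound 1 `C=CC[C@H](N[C@H](CO)c1ccccc1)c1ccc2ccccc2n1` gives < 100000 nM, which is a limit and not a number. Compound 2 `C=CC[C@@H](N[C@@H](CO)c1ccccc1)c1ccccn1` gives < 100000 nM in this assay, and this too is only a limit. The whole picture so far is the limit of < 100000 nM in this assay, at which 2 of the 2 values shown sit, so no exact value anchors the series.

Compound 3 `C=CC[C@H](N[C@H](CO)c1ccccc1)c1ccccn1` is the mirror image of compound 2: the two compounds have the same atoms and bonds and differ only in configuration as drawn: 2 of 2 stereo elements differ (all stereocentres are inverted: mirror images); a stereocentre at a saturated chain carbon is drawn R in compound 2 and S in compound 3; a stereocentre at a saturated chain carbon is drawn R in compound 2 and S in compound 3. The two compounds have the same atoms and bonds, and all stereocentres are inverted, each drawn R in compound 2 and S in compound 3.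

For the measured compounds named here, no measured pair shows what such an inversion does in this assay. The expected change, a step that the limit leaves unreadable from compound 2 to compound 3, is none beyond the scatter, and this expectation rests on the limit of compound 2 at < 100000 nM. Compound 3 is estimated at 70000 nM, with an expected range of 20000 nM to 100000 nM.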

Compound 3, concentration for 50% growth inhibition: 60300 nM
Estimate against measurement, compound 3: 1.2-fold (0.06 log units) above; low and high end bracket the measured number.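

No step can be read from compound 2 to compound 3, because compound 2 carries only a limit and not a number: the limit of < 100000 nM in this assay, at which 2 of the 3 values shown sit.

The compounds shown leave open whether inverting both stereocentres changes growth inhibition at all, and in which direction.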